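Series notes: hexyl to phenyl, cytotoxicity expectation

The source may hold more compounds than are shown below. What is called first, only, known or untested is meant among the compounds shown, and "the series" means these compounds.

Compound 1 `CCCCCCc1ccc(C(=O)N/N=C/c2ccc([N+](=O)[O-])o2)cc1` is tested in an ADME assay on U2OS cells (Homo sapiens) for cytotoxicity; on this read-out higher numbers stand for lower toxicity in this test and lower numbers for higher toxicity in this test. In this assay compound 1 gives > 200000 nM, which is a limit of the assay and not a number. Compound 2 `CCCCCCC1CCC(C(=O)N/N=C/c2ccc([N+](=O)[O-])o2)CC1` is tested in the same read-out. In this assay compound 2 gives > 200000 nM, again a limit rather than a number. Where compound 1 stands can be told only as the limit of > 200000 nM in this assay, at which 2 of the 2 values shown sit; no finite value exists in the series so far.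

Compound 3 `O=C(N/N=C/c1ccc([N+](=O)[O-])o1)c1ccc(-c2ccccc2)cc1` is yet to be measured in this assay. Its change from compound 1 is phenyl in place of hexyl on an aromatic carbon. For the measured compounds named here, no step between measured compounds is available, and both measured values are limits, so no direction can be read from the data. The step from compound 1 to compound 3 in this assay is expected to be none beyond the scatter, with compound 3 most likely again reaching the limit of the assay rather than a number. Compound 3 is estimated at 200000 nM in this assay, with a range from 80000 nM to 400000 nM. For compound 3 the expected step is a number no higher from compound 1 to compound 3 (the limit leaves the size open).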

Compound 3, half-maximal cytotoxic concentration: 109000 nM
Estimate against measurement, compound 3: 1.8-fold (0.26 log units) above; measured number inside the range.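

In this assay, for the compounds shown here, compound 3 is the first compound to give a number instead of a limit, so a group on this aromatic carbon, para to a large group, can bring the read-out into the measurable range. Phenyl in place of hexyl gives an at least 1.8-fold lower number from compound 1 to compound 3 (0.26 log units; that floor lies within the scatter) and only this floor is known for the step, so its true size stays open and no change beyond the scatter can be claimed from it. The series as shown still rests mostly on a limit and not on numbers: the limit of > 200000 nM in this assay, at which 2 of the 3 values shown sit.

The compounds shown leave open whether a number in this read-out goes with an aromatic ring at this position in general, or with phenyl alone, and a pyridine ring, a benzyl group or a cyclohexyl group in the same place would test that. They also leave open how a short chain such as butyl, a longer chain, an amine or a carboxylic acid on this aromatic carbon would read, so no trend can yet be drawn for this position.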